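From piperidin-1-yl to ethyl on a carbonyl carbon

The source may hold more compounds than are shown below. What is called first, only, known or untested is meant among the compounds shown, and "the series" means these compounds.

In a toxicity assay on NIH3T3 cells (Mus musculus) for cytotoxicity, read by resazurin assay (on this read-out lower numbers stand for an effect already at smaller amounts and higher numbers for an effect only at larger amounts of compound), three compounds are measured, each only to a limit:
Compound 1 (`CC(=O)c1ccc(NCc2cncn2Cc2ccc(-c3ccccc3)cc2)cc1-c1ccccc1`) gives > 10000 nM as a limit
Compound 2 (`N#Cc1ccc(NCc2cncn2Cc2ccc(-c3ccccc3)cc2)cc1-c1ccccc1`) gives > 1000 nM as a limit
Compound 3 (`O=C(c1ccc(NCc2cncn2Cc2ccc(-c3ccccc3)cc2)cc1-c1ccccc1)N1CCCCC1`) gives > 1000 nM as a limit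

Compound 3 has no number and stands at the limit of > 1000 nM in this assay, at which 2 of the 3 values shown sit, in the series. Compound 1 stands at the limit of > 10000 nM in this assay, at which 1 of the 3 values shown sits, as its own limit. Compound 4 (`CCC(=O)c1ccc(NCc2cncn2Cc2ccc(-c3ccccc3)cc2)cc1-c1ccccc1`) has ethyl in place of piperidin-1-yl on a carbonyl carbon, and the change counts as ethyl in place of piperidin-1-yl on a carbonyl carbon in full. The closest measured change runs the other way, with a step that the two limits leave unreadable from compound 1 to compound 3 as piperidin-1-yl replaces methyl on a carbonyl carbon. The other two measured changes, a step that the two limits leave unreadable from compound 1 to compound 2 and a step that the two limits leave unreadable from compound 2 to compound 3 as well, give no size either. For the measured compounds named here, no measured step therefore supports a direction in this assay, and none beyond the scatter is expected. The estimated step is a step that the limit leaves unreadable from compound 3 to compound 4 in this reading. For compound 4 the estimate is 10000 nM, with an expected range from 2000 nM to 30000 nM, and a limit is again the expected report.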

Compound 4, half-maximal effective concentration: > 10000 nM
Compound 4: no number, only a limit; the forecaster's own chance of this, stated with the estimate: 85%; the middle value lies on the limit itself.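

In this assay, for the compounds shown here, compound 4 gives only a limit, as do compounds 1, 2 and 3, so no new step from any of them to compound 4 can be read. The compounds shown leave open at what concentration any of them has an effect, and whether ethyl in place of piperidin-1-yl changes it.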